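Swapping the Oxazole for a Pyrazole on the Amide Nitrogen

The source may report more compounds than this note shows. Statements on the series, on what has been measured and on what is new or still open speak of the compounds shown alone.

In an assay on HEK293 cells for agonist activity at transient receptor potential cation channel subfamily M member 8 (Homo sapiens), read by fluorescence and calcium flux, with a stated time of 15 min (a higher number here means that more compound is needed for the effect, a lower number that less compound is needed), compound 1 `CCN(Cc1cccs1)C(=O)COc1ccc(C(F)(F)F)cc1` gives 236 nM, whereas compound 2 `Cc1ccc(OCC(=O)N(Cc2cccs2)c2ncco2)cc1` gives 0.3 nM, the lowest of the two numbers and far beyond the scatter from compound 1. Compound 3 `Cc1ccc(OCC(=O)N(Cc2cccs2)c2ccn[nH]2)cc1` differs from compound 2 in one place: 1H-pyrazol-5-yl in place of 1,3-oxazol-2-yl on an amide-type nitrogen. Among the compounds with values here, no measured pair shows this change, so its effect is unknown here. A moderate rise in this assay is expected for compound 3, as an estimated step of a 6.7-fold higher number from compound 2 to compound 3 (0.82 log units; beyond the scatter). Compound 3 is therefore estimated at 2 nM in this assay, with an expected range from 0.3 nM to 15 nM.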

Compound 3, half-maximal effective concentration: 0.2 nM
The estimate for compound 3 lay 10-fold (1.00 log units) above the measured number; measured number below the stated range.
By their numbers in this assay, from the lowest: compounds 3 and 2 (each within the scatter of the next); then compound 1.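

On the amide-type nitrogen, 1H-pyrazol-5-yl can take the place of 1,3-oxazol-2-yl with no difference that can be told apart in this assay: the step is a 1.5-fold lower number from compound 2 to compound 3 (0.18 log units; within the scatter), within the scatter. This position therefore tolerates a five-membered aromatic ring with a hydrogen-bond donor as well as one with none. Nothing given here explains this result.

The compounds shown leave open whether an N-methylpyrazolyl ring, which has no hydrogen on its ring nitrogens, would match these two compounds. They also leave open how an amine or a longer chain on this nitrogen would read in this assay.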